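Aryl swaps at the chain end leave cytotoxicity level

The source may report more compounds than this note shows. Statements on the series, on what has been measured and on what is new or still open speak of the compounds shown alone.

Measured in a functional assay on SK-OV-3 cells (Homo sapiens) for cytotoxicity; on this read-out higher numbers stand for weaker inhibition and lower numbers for stronger inhibition:
- compound 1 `C=C/C=C\[C@H](C)[C@H](OC(N)=O)[C@@H](C)[C@H](O)[C@@H](C)C/C(C)=C\[C@H](C)[C@@H](O)[C@@H](C)/C=C\CCc1ccc(C)c(O)c1`: 410 nM
- compound 2 `C=C/C=C\[C@H](C)[C@H](OC(N)=O)[C@@H](C)[C@H](O)[C@@H](C)C/C(C)=C\[C@H](C)[C@@H](O)[C@@H](C)/C=C\CCc1cccc(Cl)c1`: 380 nM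
- compound 3 `C=C/C=C\[C@H](C)[C@H](OC(N)=O)[C@@H](C)[C@H](O)[C@@H](C)C/C(C)=C\[C@H](C)[C@@H](O)[C@@H](C)/C=C\CCc1sccc1C`: 370 nM

Compound 3, at 370 nM, cannot be told apart from the other two compounds. Compound 4 `C=C/C=C\[C@H](C)[C@H](OC(N)=O)[C@@H](C)[C@H](O)[C@@H](C)C/C(C)=C\[C@H](C)[C@@H](O)[C@@H](C)/C=C\CCc1cccc(O)c1` has not yet been measured. It carries 3-hydroxyphenyl in place of 3-methylthiophen-2-yl on a saturated chain carbon, two bonds along the chain from a double-bonded chain carbon.

Three measured swaps at this place bear on the change: a 1.1-fold lower number from compound 1 to compound 2 (0.03 log units; within the scatter), a 1.1-fold lower number from compound 1 to compound 3 (0.04 log units; within the scatter) and a 1.0-fold lower number from compound 2 to compound 3 (0.01 log units; within the scatter). All three stay within the scatter, so no step beyond the scatter is expected in this assay. The expected step is a 1.1-fold higher number from compound 3 to compound 4 (0.03 log units; within the scatter). Compound 4 is estimated at 400 nM, with an expected range of 200 nM to 800 nM.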

Compound 4, half-maximal inhibitory concentration: 40 nM
Estimate against measurement, compound 4: 10-fold (1.00 log units) above, and the stated range ends above it.
By their numbers in this assay, from the lowest: compound 4; then compounds 3, 2 and 1 (each within the scatter of the next).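

In this assay, this place on the chain turns out to be sensitive to the aryl group after all, as 3-hydroxyphenyl in place of 3-methylthiophen-2-yl gives a 9.3-fold lower number from compound 3 to compound 4 (0.97 log units; beyond the scatter), and hydroxy in place of chloro gives a 9.5-fold lower number from compound 2 to compound 4 (0.98 log units; beyond the scatter). The hydroxy group alone is not enough, since hydrogen in place of methyl on an aromatic carbon, with the hydroxy kept, gives a 10-fold lower number from compound 1 to compound 4 (1.01 log units; beyond the scatter). Nothing available here accounts for this sharp change. As far as these compounds go, whether 3-aminophenyl or 3-methoxyphenyl in place of 3-hydroxyphenyl would keep the lower number remains open.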